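One Methoxy Removed on Two Related Cores

A few compounds are considered here, and "the series" means these few. Any claim that something is new, unique, unknown or untested is made for them only; others in the source may bear on it.

Of the compounds shown here, three of one series have been tested in a functional assay on U-87MG ATCC cells for antiproliferative activity against U-87 MG (Homo sapiens), read by MTT assay, with a stated time of 48 h, tested at 100 uM; on this read-out lower numbers stand for a stronger effect and higher numbers for a weaker effect at the one concentration tested. Compound 1 `COc1ccc(-c2nc(SCC(=O)c3sc(-c4ccccc4)nc3C)[nH]c(=O)c2C#N)cc1` gives 1.08% in this assay. Compound 2 `COc1ccc(-c2nc(SCC(=O)c3sc(-c4ccccc4)nc3C)[nH]c(=O)c2C#N)cc1OC` gives 6.48% in this assay. The two differ in a single place, (hydrogen in place of methoxy on an aromatic carbon), and the step is a number 5.4 percentage points lower from compound 2 to compound 1 (within the scatter). Compound 3 `COc1ccc(-c2nc(SCC(=O)c3sc(-c4ccc(Cl)cc4)nc3C)nc(N)c2C#N)cc1` gives 0.79% in this assay. The difference between the core of compound 3 and the core of compound 2 is not broken down here; the two values of compound 3 and compound 2 simply sit close to each other in this assay.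

Compound 4 `Cc1nc(-c2ccc(Cl)cc2)sc1C(=O)CSc1nc(N)c(C#N)c(-c2ccccc2)n1` has not yet been measured. It differs from compound 3 by hydrogen in place of methoxy on an aromatic carbon. Within the data shown here, this is the same kind of change as the one from compound 2 to compound 1, though not the same: in compound 2 the leaving methoxy sits ortho to a methoxy group and meta to a large group, whereas in compound 3 it sits para to a large group. Because the comparable step was a number 5.4 percentage points lower from compound 2 to compound 1 (within the scatter), the expected step is a number 1.2 percentage points higher from compound 3 to compound 4 (within the scatter). All three measured values lie low in this assay, and nothing among them suggests a departure for compound 4. Compound 4 is accordingly estimated at 2%, with a range from 0% to 9%.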

Compound 4, a percentage reported as activity, at one concentration (the size of the read-out at that concentration, not a potency): 4.59%
Compound 4: the middle estimate sits 2.6 percentage points below what was measured, and the stated range covers the measured number.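

In this assay, hydrogen in place of methoxy on the core of compound 3 gives a step of a number 3.8 percentage points higher from compound 3 to compound 4 (within the scatter), and set beside the earlier step on the core of compound 2, it does not stand apart from it: the same change on two cores in this assay, a number 5.4 percentage points lower (within the scatter) from compound 2 to compound 1 and a number 3.8 percentage points higher (within the scatter) from compound 3 to compound 4, 9.2 percentage points apart, within the scatter of two such steps Within this series, then, the change can be carried from one core to the other without any difference between the two cores that the read-out can resolve, and on neither core does it give a step beyond the usual scatter. This does not show that the change has no effect or that it has the same effect on both cores, since two steps that lie within the scatter can neither establish a direction nor fix a size, and all four numbers come from a single concentration, which gives no measure of potency.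

On these data alone, whether an amine, a carboxylic acid or a longer alkoxy chain in place of the methoxy would move the number clear of the scatter remains open. Also open, as far as these compounds go, is whether the four compounds would separate from one another at a lower concentration, where the read-out might distinguish what it cannot distinguish here.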